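Swapping One Diazine for Another on the Ring Carbon

The source may hold more compounds than are shown below. What is called first, only, known or untested is meant among the compounds shown, and "the series" means these compounds.

The shared core appears in compound 1 `COc1cc(C(F)(F)F)cc(SC)c1C(=O)NC1(c2ccc(C)cc2)CCCN(C)C1`, compound 2 `COc1cc(C(F)(F)F)cc(SC)c1C(=O)NC1(c2cccc(Cl)c2)CCCN(C)C1` and compound 3 `COc1cc(C(F)(F)F)cc(SC)c1C(=O)NC1(c2cnccn2)CCCN(C)C1`, which differ only in the aromatic group attached to a saturated ring carbon. In an assay on cells for inhibition of sodium- and chloride-dependent glycine transporter 1 (Homo sapiens) (a higher number here means that more compound is needed for the effect, a lower number that less compound is needed), compound 1 gives 230 nM, compound 2 gives 25 nM and compound 3 gives 1670 nM. Compound 3 stands highest of the three: a 7.3-fold higher number from compound 1 to compound 3 (0.86 log units; beyond the scatter), and a 67-fold higher number from compound 2 to compound 3 (1.82 log units; beyond the scatter), while a 9.2-fold lower number from compound 1 to compound 2 (0.96 log units; beyond the scatter). Compound 3 is thus the weakest of the measured set.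

Compound 4 `COc1cc(C(F)(F)F)cc(SC)c1C(=O)NC1(c2ccncn2)CCCN(C)C1` has not yet been measured. Its change from compound 3 is pyrimidin-4-yl in place of pyrazin-2-yl on a saturated ring carbon; the two groups hold the same atoms, joined differently. Going by the values given here, no measured step involves a swap between two such nitrogen-containing rings. The two steps that reach compound 3 both replace a substituted phenyl with pyrazin-2-yl, and each was beyond the scatter; they show that the aromatic group matters, but they give no direction for rearranging the nitrogens within it. The step of a 1.1-fold lower number from compound 3 to compound 4 (0.05 log units; within the scatter) is therefore expected to stay within the scatter. The estimate for compound 4 in this assay is 1500 nM, within a range from 400 nM to 6000 nM.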

Compound 4, half-maximal effective concentration: 1700 nM
Compound 4: middle estimate off by 1.1-fold (0.05 log units), on the low side; the range from low to high includes it.
By their numbers in this assay, from the lowest: compound 2; then compound 1; then compounds 3 and 4 (each within the scatter of the next).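

In this assay, exchanging pyrazin-2-yl for pyrimidin-4-yl on this saturated ring carbon gives a 1.0-fold higher number from compound 3 to compound 4 (0.01 log units; within the scatter) and so leaves the two groups indistinguishable here, even though their ring nitrogens are joined differently. The gap to the substituted phenyl groups therefore does not belong to pyrazin-2-yl alone, since the new group shows the same kind of separation, with a 68-fold higher number from compound 2 to compound 4 (1.83 log units; beyond the scatter) and with a 7.4-fold higher number from compound 1 to compound 4 (0.87 log units; beyond the scatter) as well, both beyond the scatter. Nothing available explains why the two nitrogen-containing rings match each other or why both stand apart from the phenyl groups.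

The compounds shown leave open whether a pyridin-2-yl group, with a single ring nitrogen, would give a number in this assay closer to that of compound 2 or to those of compound 3 and compound 4. They also leave open whether adding a chlorine to the pyrimidin-4-yl ring would bring the number down towards that of compound 2, as the 3-chlorophenyl group stands lowest of this set.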